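Replacing the urea arm of compound 3: an expectation

The source may report more compounds than this note shows. Statements on the series, on what has been measured and on what is new or still open speak of the compounds shown alone.

Compound 3 `COc1cc(Cl)cc(-c2nn(-c3cccc(NC(=O)Nc4ccc(Cl)c(Cl)c4)c3)cc2-c2ccncc2)c1` is measured in a functional assay on KM12 cells (Homo sapiens) for inhibition, read by sulforhodamine B assay, with a stated time of 48 h, tested at 1 uM (a lower number here means a stronger effect, a higher number a weaker effect of the compound at the concentration tested), where compound 3 gives 72%. Compound 1 `O=C(Nc1cccc(-n2cc(-c3ccncc3)c(-c3cc(O)cc(Cl)c3)n2)c1)Nc1ccc(Cl)c(Cl)c1` gives 72% in this assay, and compound 2 `COc1cc(Cl)cc(-c2nn(-c3cccc(NC(=O)Nc4ccc(Cl)c(C(F)(F)F)c4)c3)cc2-c2ccncc2)c1` gives 33%. Compound 3 thus stands level with compound 1, the two together being the highest of the three numbers, while compound 2 lies furthest away. The steps of no change at the digits printed from compound 1 to compound 3 (within the scatter) and a number 39 percentage points higher from compound 2 to compound 3 (beyond the scatter) frame its position. Compound 4 `COc1cc(Cl)cc(-c2nn(-c3cccc(NC(=O)c4cccc(C(F)(F)F)c4)c3)cc2-c2ccncc2)c1` differs from compound 3 by 3-(trifluoromethyl)phenyl in place of (3,4-dichlorophenyl)amino on a carbonyl carbon. For the measured compounds named here, the step of a number 39 percentage points higher from compound 2 to compound 3 (beyond the scatter), which also turns on a trifluoromethyl group, is the one measured step that bears on this change, and it was large; the loss of the (3,4-dichlorophenyl)amino group has no measured counterpart. A step of a number 20 percentage points lower from compound 3 to compound 4 (beyond the scatter) is expected, toward a lower number. Compound 4 is therefore estimated at 52%, between 22% and 85%.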

Compound 4, a percentage reported as activity, at one concentration (the size of the read-out at that concentration, not a potency): 56%
Compound 4: the middle estimate sits 4 percentage points below what was measured; the range from low to high includes it.
By their numbers in this assay, from the lowest: compound 2; then compound 4; then compounds 1 and 3 (each within the scatter of the next).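

In this assay, the (3,4-dichlorophenyl)amino group on the carbonyl carbon can give way to 3-(trifluoromethyl)phenyl, which has no urea nitrogen there, with a number 16 percentage points lower from compound 3 to compound 4 (beyond the scatter) as the result. The same kind of exchange, starting from the (4-chloro-3-(trifluoromethyl)phenyl)amino group, gives a number 23 percentage points higher from compound 2 to compound 4 (beyond the scatter), so the direction depends on the urea it replaces. Nothing measured here explains either step. On these data alone, what remains open is whether the urea nitrogen or the ring substituents drive these shifts. Also open, as far as these compounds go, is how a morpholine or a longer alkyl chain on that carbonyl carbon would read.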